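Trimming the hydroxyl: from compound 1 to compound 4

This account rests on a few compounds, and the source may have more. Where it says the series, first, only, none or still open, it means among the compounds named here.

Compound 1 `OCCNc1nccc2c1ncn2C1O[C@H](CO)[C@@H](O)[C@H]1O` has the lower of the two numbers in a functional assay on EL4 cells (Mus musculus) for inhibition, tested at 100 uM (on this read-out higher numbers stand for more inhibition at the one concentration tested (going by the name of the read-out) and lower numbers for less inhibition), where compound 1 gives 6%. Compound 2 `CCCCCCNc1[nH]ccc2ncnc1-2` gives 100% in this assay. For compound 3 `Sc1[nH]ccc2ncnc1-2` this assay reports only a limit, < 5%. That is the limit at which (the limit of < 5% in this assay, at which 1 of the 3 values shown sits). Going by the values given here, no pair of measured compounds differing in a single place is available, so no measured step tells how large a change of the present kind is. Compound 4 `CCNc1nccc2c1ncn2C1O[C@H](CO)[C@@H](O)[C@H]1O` differs from compound 1 in one place: hydrogen in place of hydroxy on a saturated chain carbon, two bonds along the chain from a nitrogen on an aromatic ring. The expected step of a number 4 percentage points higher from compound 1 to compound 4 (within the scatter) is small and not beyond the scatter. The estimate for compound 4 is 10%, between 0% and 30%.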

Compound 4, a percentage reported as inhibition, at one concentration (the size of the read-out at that concentration, not a potency): 8%
Compound 4: middle estimate off by 2 percentage points, on the high side; low and high end bracket the measured number.
By their numbers in this assay, from the lowest: compounds 1 and 4 (each within the scatter of the next); then compound 2. At a limit, below all of these: compound 3.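

In this assay, going by these compounds alone, going from (2-hydroxyethyl)amino to ethylamino gives a number 2 percentage points higher from compound 1 to compound 4 (within the scatter), the first measured step at this position. On this core, removing the hydroxy therefore does not lift the inhibition out of the low range. Compound 3 gives only a limit, and this step is read not far from that floor, so a further loss would be hard to see: the limit of < 5% in this assay, at which 1 of the 4 values shown sits.

Still open, going by these compounds, is whether an amine or a carboxylic acid in place of the hydroxy would move the number. On these data alone, a longer chain on this same core is equally open.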